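Fluoro in place of hydrogen on compound 1

The source may report more compounds than this note shows. Statements on the series, on what has been measured and on what is new or still open speak of the compounds shown alone.

Compound 1 `COc1ccc2c(=O)cc(-c3ccccc3)oc2c1` gives 5.9 mg/kg
Compound 2 `COc1ccccc1-c1cc(=O)c2ccccc2o1` gives 22.4 mg/kg

Of the two compounds measured in a functional assay on the whole organism with Rattus norvegicus as the target (on this read-out lower numbers stand for an effect already at smaller amounts and higher numbers for an effect only at larger amounts of compound), compound 1 has the lower number, and compound 2 lies above it by more than the scatter. Compound 3 `COc1ccc2c(=O)cc(-c3ccc(F)cc3)oc2c1` differs from compound 1 by one change (fluoro in place of hydrogen on an aromatic carbon), with fluoro in place of hydrogen on an aromatic carbon, para to a large group. For the measured compounds named here, no measured pair shows this change, so the expectation rests on compound 1 at 5.9 mg/kg and on the smallness of the change. No step beyond the scatter is expected in this assay, and no direction can be argued from the data. The expected step of a 1.1-fold lower number from compound 1 to compound 3 (0.03 log units; within the scatter) is therefore small. The estimate for compound 3 is 5.5 mg/kg, with an expected range from 2.5 mg/kg to 12 mg/kg as its limits.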

Compound 3, dose for half-maximal effect: 8.9 mg/kg
Compound 3: the middle estimate sits 1.6-fold (0.21 log units) below what was measured, and the stated range covers the measured number.
By their numbers in this assay, from the lowest: compounds 1 and 3 (each within the scatter of the next); then compound 2.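

In this assay, for the compounds shown here, fluoro in place of hydrogen on an aromatic carbon, para to a large group, gives a 1.5-fold higher number from compound 1 to compound 3 (0.18 log units; within the scatter) and is the only step between measured compounds that differ in one place. This carbon of the six-membered aromatic ring therefore takes fluoro without a step beyond the scatter, and the read-out does not separate compound 3 from compound 1. Nothing available bears on why fluoro has this outcome at this carbon.

A single small substituent at one carbon leaves open whether an amine, a carboxylic acid or a longer chain at the same place would also stay within the scatter of compound 1. Also open, from the compounds shown here alone, is whether fluoro on the other carbons of this ring would give a step of similar size.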